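A Rearranged Tail on Compound 3, Near the Limit

The compounds below may be only part of what the source reports. "The series", "measured", "known", "first", "only" and "open" are said of these compounds alone.

Three measured compounds share one core and differ only in the chain and the nitrogen-rich group at its far end. In a functional assay on the whole organism (stomach) with Rattus norvegicus as the target (a higher number here means that more compound is needed for the effect, a lower number that less compound is needed), compound 1 `CC/N=C(/NC#N)NCCCCCn1nc(-c2ccccc2)ccc1=O` gives 100 mg/kg. Compound 2 `CCC/N=C(/NC#N)NCCCCCn1nc(-c2ccccc2)ccc1=O` reaches only a limit of this assay, recorded as > 100 mg/kg. Compound 3 `CC/N=C(/NC#N)NCCCCCCn1nc(-c2ccccc2)ccc1=O` likewise yields only a limit, > 100 mg/kg. The steps among them are therefore hard to read: a number no lower from compound 1 to compound 2 (the limit leaves the size open), a number no lower from compound 1 to compound 3 (the limit leaves the size open) and a step that the two limits leave unreadable from compound 2 to compound 3. The whole set sits close to the limit of > 100 mg/kg in this assay, at which 2 of the 3 values shown sit, so compound 3 stands at the top edge of what this assay can report, with no number of its own.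

Compound 4 `CN(C)/C(=N/CCCCCCn1nc(-c2ccccc2)ccc1=O)NC#N` is built from compound 3 by a group of 8 heavy atoms (4 carbon, 4 nitrogen; no ring) in place of a group of 8 heavy atoms (4 carbon, 4 nitrogen; no ring), on a saturated chain carbon, six bonds along the chain from an aromatic nitrogen; the two have the same atoms, joined differently. Going by the values given here, no measured step involves a change of this kind, and the two steps that touch the same chain end are both unreadable limits. Among the compounds with values here, nothing among the measured values points toward a large gain, so compound 4 is expected to show a number no higher from compound 3 to compound 4 (the limit leaves the size open), that is, no step beyond the scatter. Compound 4 is estimated at 100 mg/kg, with a range from 50 mg/kg to 200 mg/kg, and most probably again only a limit in this assay.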

Compound 4, dose for half-maximal effect: 93.1 mg/kg
Compound 4: middle estimate off by 1.1-fold (0.03 log units), on the high side; the range from low to high includes it.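

Rearranging the same atoms, so that the group on the saturated chain carbon, six bonds along the chain from an aromatic nitrogen, has 1 hydrogen-bond donor instead of 2, gives compound 4 a readable number in this assay where compound 3 has only a limit. The change registers as an at least 1.0-fold lower number from compound 3 to compound 4 (0.03 log units; that floor lies within the scatter) and as an at least 1.0-fold lower number from compound 2 to compound 4 (0.03 log units; that floor lies within the scatter) while the one comparison between two actual numbers is a 1.1-fold lower number from compound 1 to compound 4 (0.03 log units; within the scatter) so no gain beyond the scatter is shown. This position therefore tolerates the rearrangement without any demonstrated change, and the set as a whole stays at the top edge of what the assay can report: the limit of > 100 mg/kg in this assay, at which 2 of the 4 values shown sit.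

On these data alone, the steps that rest on limits alone cannot be read, so it stays open whether compound 2 and compound 3 truly differ from compound 4 or how far they lie from it. As far as these compounds go, it is also open whether a longer chain, or an amine or a carboxylic acid in place of the entering group, would move the number clearly away from that edge.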